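A Urea Gives Way to a Phenyl-Triazole

The source may hold more compounds than are shown below. What is called first, only, known or untested is meant among the compounds shown, and "the series" means these compounds.

Compound 2 `COc1ccc(-c2c(C)nc3c(N4CC[C@@H](NC(=O)NC(C)C)C4)cc(C)nn23)cc1OC` was tested in an ADME assay on microsomes from liver (Mus musculus) for metabolic stability, read by LC-MS, with NADPH named in the record, with a stated time of 60 min, tested at 1 uM, in the absence of a further agent; on this read-out higher numbers stand for a more stable compound and lower numbers for a less stable compound. In this assay compound 2 gives > 95%, which is a limit of the assay rather than a number. Compound 1 `COc1ccc(-c2c(C)nc3c(N4CC[C@@H](NC(C)=O)C4)cc(C)nn23)cn1` also gives > 95%, again a limit. Both measured values therefore sit at the limit of > 95% in this assay, at which 2 of the 2 values shown sit. Compound 3 `COc1ccc(-c2c(C)nc3c(N4CC[C@@H](n5cc(-c6ccccc6)nn5)C4)cc(C)nn23)cc1OC` has not been measured and differs from compound 2 in one place: 4-phenyl-1H-1,2,3-triazol-1-yl in place of (isopropylcarbamoyl)amino on a saturated ring carbon. Within the data shown here, because no step between measured compounds is available, the expected step of a number at least 15 percentage points lower from compound 2 to compound 3 (beyond the scatter) is a moderate loss of stability beyond the scatter. Compound 3 is expected to give about 80%, between 55% and 95%.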

Compound 3, percent of the compound remaining: "unstable" (no number reported)
Compound 3: no number reported, so the estimate cannot be set against anything.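

Among these compounds, compound 3 is recorded only as unstable, without a number, and compound 2 only as a limit, so no step from compound 2 to compound 3 can be read. From the compounds shown here alone, the size of any difference in stability between them stays open.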